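Methyl to Methoxy on the Side Chain of Compound 2

The source may hold more compounds than are shown below. What is called first, only, known or untested is meant among the compounds shown, and "the series" means these compounds.

Measured compounds:
compound 1, `CCCc1cccc(C[C@H](O)/C=C/[C@H]2CCC(=S)N2CCCCCCC(=O)O)c1`, > 10000 nM in an assay on CHO cells for displacement of a labelled ligand from prostaglandin E2 receptor EP1 subtype (Mus musculus), read by scintillation counting, with a stated time of 20 min; on this read-out higher numbers stand for weaker inhibition and lower numbers for stronger inhibition
compound 2, `CCc1cccc(C[C@H](O)/C=C/[C@H]2CSC(=O)N2CCSCCCC(=O)O)c1`, 4600 nM in this assay

Compound 1 gives only a limit in this assay, (the limit of > 10000 nM in this assay, at which 1 of the 2 values shown sits), so no number is attached to it. Going by the values given here, compound 2 holds the only number in the set, and that number, 4600 nM, describes a weak binder. Among the compounds with values here, no step between two measured compounds is available, so the effect of any single change has to be guessed from the structures alone.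

Compound 3, `COCc1cccc(C[C@H](O)/C=C/[C@H]2CSC(=O)N2CCSCCCC(=O)O)c1`, has not yet been measured. It differs from compound 2 in one place: methoxy in place of methyl on a saturated chain carbon bound to an aromatic carbon. The two share everything else, including the core and the acid chain.

With nothing measured on this kind of change, the expected step from compound 2 to compound 3 is small, a 1.3-fold higher number from compound 2 to compound 3 (0.12 log units; within the scatter), not clearly beyond the usual scatter and, if anything, toward weaker binding. The estimate for compound 3 is therefore 6000 nM, within a range from 2000 nM to 20000 nM.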

Compound 3, inhibition constant: > 10000 nM
Compound 3 was reported as a limit; the forecaster's own chance of this, stated with the estimate: 30%; middle value at least 1.6-fold (0.22 log units) from the limit.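

Going by these compounds alone, replacing methyl with methoxy on a saturated chain carbon bound to an aromatic carbon gives the only readable step in this set, in this assay: an at least 2.1-fold higher number from compound 2 to compound 3 (0.33 log units; beyond the scatter). This shows that binding at this position does not tolerate every small change, as the swap adds one oxygen and one hydrogen-bond acceptor and binding weakens in this single pair. The full size of the loss stays unknown, since compound 3 gives only a limit and not a number: the limit of > 10000 nM in this assay, at which 2 of the 3 values shown sit.

This one pair cannot separate the effect of the oxygen from that of the larger group, and a comparison with a plain propyl group on the same core would address that. On these data alone, whether an amine or a nitrile at this position would fare better or worse also remains open.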